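The source may report more compounds than this note shows. Statements on the series, on what has been measured and on what is new or still open speak of the compounds shown alone.

In a functional assay on MCF7 cells (Homo sapiens) for antiproliferative activity, read by MTT assay, with a stated time of 72 h (a lower number here means a stronger inhibitor, a higher number a weaker inhibitor), the measured compounds are:
Compound 1 `COc1cc(-n2cnc3ccc(-c4ccc(C)cc4F)cc32)cc(OC)c1OC`: 56 nM
Compound 2 `COc1cc(-n2cnc3ccc(-c4ccc([N+](=O)[O-])cc4)cc32)cc(OC)c1OC`: 740 nM

For the measured compounds named here, compound 2 holds the higher of the two numbers, and compound 1 is its only measured neighbour. Compound 3 `COc1cc(-n2cnc3ccc(-c4ccc(C(F)(F)F)cc4)cc32)cc(OC)c1OC` is not yet measured. It carries trifluoromethyl in place of nitro on an aromatic carbon, para to a large group (trifluoromethyl in place of nitro on an aromatic carbon). Going by the values given here, one measured step bears on this: a 13-fold higher number from compound 1 to compound 2 (1.12 log units; beyond the scatter) and it is large, yet it exchanged a whole aromatic group and shows nothing about trifluoromethyl alone. Starting from compound 2 at 740 nM a smaller step toward a lower number in this assay is expected, not a full return to the level of compound 1. The expected change is a 3.0-fold lower number from compound 2 to compound 3 (0.47 log units; beyond the scatter) and this remains an estimate. Compound 3 is expected at 250 nM with an estimated range from 70 nM to 800 nM in this measurement.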

Compound 3, half-maximal inhibitory concentration: 760 nM
Compound 3: middle estimate off by 3.0-fold (0.48 log units), on the low side; low and high end bracket the measured number.
By their numbers in this assay, from the lowest: compound 1; then compounds 2 and 3 (each within the scatter of the next).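

In this assay, trifluoromethyl and nitro on this aromatic carbon, para to a large group, cannot be told apart, with a 1.0-fold higher number from compound 2 to compound 3 (0.01 log units; within the scatter) as the reading for this exchange. For the compounds shown here, the earlier compounds could not show this, since their one step exchanged a whole aromatic group. The 2-fluoro-4-methylphenyl compound now also stands apart from a second compound, with a 14-fold higher number from compound 1 to compound 3 (1.13 log units; beyond the scatter) as the step, and nothing measured here gives a reason for either result.

The compounds shown leave open whether the fluorine or the methyl of that group carries the lower number of compound 1. They also leave open how an amine, a carboxylic acid or a simple methyl group would read in the place of nitro.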